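The compounds below may be only part of what the source reports. "The series", "measured", "known", "first", "only" and "open" are said of these compounds alone.

Of the compounds shown here, two sharing one core have been tested in an assay on isolated protein for inhibition of histone deacetylase 8 (Homo sapiens), read by fluorescence, with a stated time of 10 min; on this read-out lower numbers stand for stronger inhibition and higher numbers for weaker inhibition. Compound 1 `COc1ccc(-c2noc(CCCCCCC(=O)NO)n2)cc1` reaches only the assay limit of > 10000 nM. That is the limit of > 10000 nM in this assay, at which 1 of the 2 values shown sits. Within the data shown here, compound 2 `O=C(CCCCCCc1nc(-c2cccc([N+](=O)[O-])c2)no1)NO` gives 2380 nM, the only actual number among the two results. Compound 3 `Nc1ccccc1NC(=O)CCCCCCc1nc(-c2cccc([N+](=O)[O-])c2)no1` differs from compound 2 by 2-aminophenyl in place of hydroxy on an amide-type nitrogen. Among the measured compounds shown here, no measured pair shows this exchange here, so the step is expected to weaken inhibition well beyond the scatter, an 8.4-fold higher number from compound 2 to compound 3 (0.92 log units; beyond the scatter). Compound 3 is therefore estimated at 20000 nM, within 5000 nM to 100000 nM, and may well come back only as a limit.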

Compound 3, half-maximal inhibitory concentration: > 10000 nM
Compound 3: a limit, no number; the forecaster's own chance of this, stated with the estimate: 70%; the middle value lies beyond the limit too.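

Among these compounds, putting 2-aminophenyl in place of hydroxy on an amide-type nitrogen clearly weakens inhibition, with an at least 4.2-fold higher number from compound 2 to compound 3 (0.62 log units; beyond the scatter), the first measured step at this place. Compound 3 gives only a limit, not a number: the limit of > 10000 nM in this assay, at which 2 of the 3 values shown sit.

The real size of the loss therefore stays unknown, and among the compounds shown only compound 2, with its hydroxycarbamoyl end, gives an actual number. Open, going by these compounds, is whether a plain phenyl or a methyl on this nitrogen, or a carboxylic acid in place of the whole hydroxycarbamoyl end, would keep any inhibition. A longer chain is equally untested here.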